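Swapping Trifluoromethyl for Chloro on a Fused Core

The compounds below may be only part of what the source reports. "The series", "measured", "known", "first", "only" and "open" are said of these compounds alone.

Compound 1 `CC(C(=O)O)c1nn(Cc2cn3cc(OCC4CC4)c(C(F)(F)F)cc3n2)c2ccccc2c1=O` gives 3.4 nM.
Compound 2 `O=C(O)Cn1nc(Cc2nc3cc(Cl)c(OCC4CC4)cc3[nH]2)c2ccccc2c1=O` gives 8.8 nM.

Both were tested in a functional assay on CHO cells for antagonist activity at sphingosine 1-phosphate receptor 2 (Homo sapiens), read by calcium flux; on this read-out higher numbers stand for weaker inhibition and lower numbers for stronger inhibition. Compound 1 stands at the lowest number of the two; the nearest, compound 2, lies at a higher number, beyond the scatter. Compound 3 `CC(C(=O)O)c1nn(Cc2cn3cc(OCC4CC4)c(Cl)cc3n2)c2ccccc2c1=O` has not yet been measured in this assay. It differs from compound 1 in one place: chloro in place of trifluoromethyl on an aromatic carbon. Compound 2 differs from compound 1 in more than one place, so it offers no direct measure of this change. A modest weakening is expected, roughly at the edge of the scatter, a 1.8-fold higher number from compound 1 to compound 3 (0.25 log units; within the scatter). Compound 3 is therefore estimated at 6 nM, between 2 nM and 20 nM.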

Compound 3, half-maximal inhibitory concentration: 6 nM
Compound 3: middle estimate and measured number agree at the digits printed, within the range that was stated.
By their numbers in this assay, from the lowest: compounds 1, 3 and 2 (each within the scatter of the next, the first and the last beyond it).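

In this assay, the position ortho to the cyclopropylmethoxy group accepts chloro in place of trifluoromethyl, with a 1.8-fold higher number from compound 1 to compound 3 (0.25 log units; within the scatter), so the read-out does not separate the single chlorine atom from the four-atom group. This holds for this one pair on the core of compound 1. Nothing measured here explains the result. As far as these compounds go, whether a smaller or different group at this position, such as a methyl, a methoxy or a nitrile, would also stay in this range remains open.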